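Triazole aryl variation on a hydroxylated triterpenoid ester

A few compounds are considered here, and "the series" means these few. Any claim that something is new, unique, unknown or untested is made for them only; others in the source may bear on it.

Compound 1 `C/C(=C\CC/C(C)=C/CC[C@@H]1[C@@]2(C)CCC(=O)C(C)(C)[C@H]2CC[C@@]1(C)O)CC/C=C(\C)C(=O)OCc1cn(-c2ccc(F)c(Cl)c2)nn1` is the reference point for the step to compound 4. In a functional assay on A549 cells (Homo sapiens) for antiproliferative activity, read by MTT assay, with a stated time of 48 h (a lower number here means a stronger inhibitor, a higher number a weaker inhibitor), compound 1 gives > 150000 nM, which is a limit of the assay and not a number. Compound 2 `C/C(=C\CC/C(C)=C/CC[C@@H]1[C@@]2(C)CCC(=O)C(C)(C)[C@H]2CC[C@@]1(C)O)CC/C=C(\C)C(=O)OCc1cn(-c2cccc([N+](=O)[O-])c2)nn1` gives > 150000 nM in this assay, again a limit. Going by the values given here, compound 3 `C/C(=C\CC/C(C)=C/CC[C@@H]1[C@@]2(C)CCC(=O)C(C)(C)[C@H]2CC[C@@]1(C)O)CC/C=C(\C)C(=O)OCc1cn([C@@H]2C[C@@H](n3cc(C)c(=O)[nH]c3=O)O[C@H]2CO)nn1` gives 35000 nM in this assay, the one numerical value of the three. The step from compound 1 to compound 2 is a step that the two limits leave unreadable from compound 1 to compound 2, so the swap of one aryl group for another on the aromatic nitrogen leaves no readable size; both values sit at the limit of > 150000 nM in this assay, at which 2 of the 3 values shown sit.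

Compound 4 `C/C(=C\CC/C(C)=C/CC[C@@H]1[C@@]2(C)CCC(=O)C(C)(C)[C@H]2CC[C@@]1(C)O)CC/C=C(\C)C(=O)OCc1cn(-c2ccc(Cl)cc2)nn1` differs from compound 1 by 4-chlorophenyl in place of 3-chloro-4-fluorophenyl on an aromatic nitrogen. Among the compounds with values here, only the step from compound 1 to compound 2 bears on this change, and it is unreadable; the two aryl-substituted compounds show no measurable activity. The expected step from compound 1 to compound 4 is therefore a number no higher from compound 1 to compound 4 (the limit leaves the size open), no shift beyond the scatter. Compound 4 is estimated at 150000 nM, with a range from 60000 nM to 400000 nM, most likely reported as a limit.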

Compound 4, half-maximal inhibitory concentration: > 150000 nM
Compound 4 ended at the assay's limit; the forecaster's own chance of this, stated with the estimate: 75%; the middle value sits exactly at the limit.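

Compound 4 gives > 150000 nM in this assay, a limit of the assay and not a number, so the steps to compound 4 from compound 1 and compound 2 cannot be read: the limit of > 150000 nM in this assay, at which 3 of the 4 values shown sit.

The compounds shown leave open whether these three aryl groups on the aromatic nitrogen differ at all in activity.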